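Swapping a methylsulfonyl pyridine for a cyanopyrazine

The source may hold more compounds than are shown below. What is called first, only, known or untested is meant among the compounds shown, and "the series" means these compounds.

Compound 3 `CC(C)(C)OC(=O)N1CCC(O[C@H]2CC[C@H](Oc3ccc(S(C)(=O)=O)cn3)CC2)CC1` gives 47 nM in a functional assay on isolated protein for agonist activity at Glucose-dependent insulinotropic receptor (Homo sapiens), read by HTRF and cAMP accumulation (a lower number here means that less compound is needed, a higher number that more compound is needed for the effect), the second highest of three numbers: compound 2 `CC(C)(C)OC(=O)N1CCC(O[C@H]2CC[C@H](Oc3ccc(S(C)(=O)=O)cc3F)CC2)CC1` gives 8.5 nM, and compound 1 `CC(C)(C)OC(=O)N1CCC(O[C@H]2CC[C@@H](Oc3ccc(S(C)(=O)=O)cc3)CC2)CC1` gives 266 nM. Compound 4 `CC(C)(C)OC(=O)N1CCC(O[C@H]2CC[C@H](Oc3cnc(C#N)cn3)CC2)CC1` has not been measured yet; it carries 5-cyanopyrazin-2-yl in place of 5-(methylsulfonyl)pyridin-2-yl on an oxygen on a saturated carbon. Within the data shown here, no measured pair shows this kind of exchange, so the size of the step is uncertain. A change of a similar aromatic group, as between compound 3 and compound 2, gave a clear shift, and here the methylsulfonyl gives way to a nitrile on a ring with one more nitrogen. A modest step upward in number from compound 3 to compound 4 is expected, near a 1.9-fold higher number from compound 3 to compound 4 (0.28 log units; within the scatter). Compound 4 is estimated at 90 nM, between 25 nM and 350 nM.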

Compound 4, half-maximal effective concentration: 8.3 nM
Compound 4: middle estimate off by 11-fold (1.04 log units), on the high side, outside the stated range (below it).
By their numbers in this assay, from the lowest: compounds 4 and 2 (each within the scatter of the next); then compound 3; then compound 1.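

In this assay, the methylsulfonyl group is not needed for a low number at this position: 5-cyanopyrazin-2-yl gives a 5.7-fold lower number from compound 3 to compound 4 (0.75 log units; beyond the scatter) and so replaces it with a gain. Compound 4 at 8.3 nM and compound 2 at 8.5 nM lie within the scatter of each other, so an aromatic group without sulfur can match this sulfone. The data shown offer no reason for the step.

From the compounds shown here alone, the exchange alters the ring and its substituent together, so the share of each stays open. A 5-cyanopyridin-2-yl group on the same oxygen would separate them.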